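Replacing 3-hydroxypropyl with hydroxy on an amide-type nitrogen

A few compounds are considered here, and "the series" means these few. Any claim that something is new, unique, unknown or untested is made for them only; others in the source may bear on it.

In a functional assay on HCT-116 cells (Homo sapiens) (on this read-out lower numbers stand for stronger inhibition and higher numbers for weaker inhibition), compound 1 (`COc1cc(NC(C)CCCNC(=O)NCCCO)c2ncccc2c1`) gives > 100000 nM, which is a limit of the assay and not a number. It is the only such case in this small set: the limit of > 100000 nM in this assay, at which 1 of the 3 values shown sits. Its true position is therefore unknown, and any step that starts from it has only a bound.

The other two measured compounds give numbers. Compound 2 (`COc1cc(NC(C)CCCNC(=O)NOCc2ccccc2)c2ncccc2c1`) gives 14000 nM, and compound 3 (`COc1cc(NC(C)CCCNC(=O)NCCNC(=O)NCCCC(C)Nc2cc(OC)cc3cccnc23)c2ncccc2c1`) gives 15000 nM.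

Compound 4 (`COc1cc(NC(C)CCCNC(=O)NO)c2ncccc2c1`) has not yet been measured. It differs from compound 1 by hydroxy in place of 3-hydroxypropyl on an amide-type nitrogen.

Within the data shown here, one measured step bears on this change. At the same nitrogen, benzyloxy in place of 3-hydroxypropyl gives an at least 7.1-fold lower number from compound 1 to compound 2 (0.85 log units; beyond the scatter). Compound 4 resembles compound 2 in carrying an oxygen-linked group on that nitrogen, so a step of similar size towards stronger inhibition is expected, though this rests on a single step that starts from a limit.

The expected step is an at least 5.0-fold lower number from compound 1 to compound 4 (0.69 log units; beyond the scatter).

For compound 4 the estimated value is 20000 nM, with an expected range from 5000 nM to 80000 nM.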

Compound 4, half-maximal inhibitory concentration: 57000 nM
Estimate against measurement, compound 4: 2.9-fold (0.45 log units) below; low and high end bracket the measured number.
By their numbers in this assay, from the lowest: compounds 2 and 3 (each within the scatter of the next); then compound 4. At a limit, above all of these: compound 1.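

Hydroxy on the amide-type nitrogen gives a number where 3-hydroxypropyl gave only a limit, yet this does not establish a real gain, since the step reads an at least 1.7-fold lower number from compound 1 to compound 4 (0.24 log units; that floor lies within the scatter). The comparison with the benzyloxy compound is firmer: in this assay, hydrogen in place of benzyl on the oxygen gives a 4.1-fold higher number from compound 2 to compound 4 (0.61 log units; beyond the scatter), so an oxygen on that nitrogen does not alone bring the read-out to the level of compound 2, and the benzyl on it also makes a difference. The true size of the step from 3-hydroxypropyl to hydroxy stays unknown because compound 1 is held at a limit of the assay, not a number: the limit of > 100000 nM in this assay, at which 1 of the 4 values shown sits.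

The compounds shown leave open whether the difference between hydrogen and benzyl on the oxygen depends on the phenyl ring or would also appear with a plain methyl or a longer alkyl chain there. They also leave open whether the oxygen is needed at all, which a benzyl group placed directly on the amide-type nitrogen would address.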